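Formylamino in Place of Thiazolidinedione: Lipophilicity Expectation

A few compounds are considered here, and "the series" means these few. Any claim that something is new, unique, unknown or untested is made for them only; others in the source may bear on it.

Of the compounds shown here, three sharing one core have been measured in a physicochemical assay for lipophilicity, read by HPLC, measured as octanol-water partition; a lower number here means a more polar compound, a higher number a more lipophilic compound. Compound 1 `O=C1O[C@@H](CO)CN1c1ccc(-n2cc(-c3ccccn3)cn2)c(F)c1` gives 1.67. Compound 2 `O=C1O[C@@H](CN2CCC(O)CC2)CN1c1ccc(-n2cc(-c3ccccn3)cn2)c(F)c1` gives 1.63, and compound 3 `O=C1CSC(=O)N1C[C@H]1CN(c2ccc(-n3cc(-c4ccccn4)cn3)c(F)c2)C(=O)O1` gives 2.18. Compound 3 stands highest of the three: the change from compound 1 to compound 3 reads a number 0.51 log units higher from compound 1 to compound 3 (beyond the scatter), and the change from compound 2 to compound 3 reads a number 0.55 log units higher from compound 2 to compound 3 (beyond the scatter), while between compound 1 and compound 2 the difference is a number 0.04 log units lower from compound 1 to compound 2 (within the scatter), so those two cannot be told apart.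

Compound 4 `O=CNC[C@H]1CN(c2ccc(-n3cc(-c4ccccn4)cn3)c(F)c2)C(=O)O1` has not yet been measured. It differs from compound 3 in one place: formylamino in place of 2,4-dioxo-1,3-thiazolidin-3-yl on a saturated chain carbon bound to a saturated ring carbon. For the measured compounds named here, the steps that bear on this are the two in which the same thiazolidinedione group was set against a smaller group on the same chain carbon, a number 0.51 log units higher from compound 1 to compound 3 (beyond the scatter) and a number 0.55 log units higher from compound 2 to compound 3 (beyond the scatter); in both, the compound carrying the ring with its two carbonyls came out higher by a modest margin. The incoming group here is likewise small and has no ring. The expected step is therefore a number 0.68 log units lower from compound 3 to compound 4 (beyond the scatter), a modest decrease in the partition coefficient. For compound 4 the value in this assay is estimated at 1.5, with a likely range from 1.1 to 1.9.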

Compound 4, partition coefficient: 1.19
Estimate against measurement, compound 4: 0.31 log units above; the measured number falls inside the stated range.
By their numbers in this assay, from the lowest: compound 4; then compounds 2 and 1 (each within the scatter of the next); then compound 3.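

In this assay, formylamino gives the first clear separation from the two groups that could not be told apart at this place, with steps of a number 0.48 log units lower from compound 1 to compound 4 (beyond the scatter) and a number 0.44 log units lower from compound 2 to compound 4 (beyond the scatter). Together with a number 0.99 log units lower from compound 3 to compound 4 (beyond the scatter), the largest step in the set, this shows that a small group without a ring can also shift the number on a saturated chain carbon bound to a saturated ring carbon, and that being small and ringless does not fix the value, since hydroxy in compound 1 stands higher than formylamino in compound 4. No measurement available here accounts for the position of formylamino in this order.

An acetylamino group or a plain amine on the same chain carbon would show whether this low number is particular to formylamino or extends to close relatives of it. As far as these compounds go, all four compounds share one core, so whether the same order of groups would hold on a different core remains open.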